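Substituted Aryl Sulfides in a Thromboxane Synthase Series

This account rests on a few compounds, and the source may have more. Where it says the series, first, only, none or still open, it means among the compounds named here.

Of the compounds shown here, three sharing one core have been measured in an assay for inhibition of Thromboxane-A synthase (Homo sapiens), using microsomes; a higher number here means a weaker inhibitor, a lower number a stronger inhibitor. Compound 1 `CC(C)(Oc1ccc(F)cc1)C1OCC(C/C=C\CCC(=O)O)C(c2cccnc2)O1` gives 51 nM, compound 2 `CSc1ccccc1OC(C)(C)C1OCC(C/C=C\CCC(=O)O)C(c2cccnc2)O1` gives 36 nM, and compound 3 `CC(C)(Sc1ccccc1)C1OCC(C/C=C\CCC(=O)O)C(c2cccnc2)O1` gives 40 nM. Compound 3 therefore holds the second highest of the three numbers, yet all three lie within the scatter of one another: the step of a 1.4-fold lower number from compound 1 to compound 2 (0.15 log units; within the scatter), the step of a 1.3-fold lower number from compound 1 to compound 3 (0.11 log units; within the scatter) and the step of a 1.1-fold higher number from compound 2 to compound 3 (0.05 log units; within the scatter) are each too small to count as a real difference.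

Compound 4 `COc1ccc(SC(C)(C)C2OCC(C/C=C\CCC(=O)O)C(c3cccnc3)O2)c([N+](=O)[O-])c1` carries 4-methoxy-2-nitrophenyl in place of phenyl on a sulfur. For the measured compounds named here, no measured step changes the substitution of the aryl group on the sulfur, so none bears on it directly. What the measured steps do show is that exchanging a 4-fluorophenoxy for a phenylsulfanyl, or a 4-fluorophenyl for a 2-(methylsulfanyl)phenyl, left this assay unmoved. On that basis the expected step of no change at the digits printed from compound 3 to compound 4 (within the scatter) is none beyond the scatter, with a wide margin given that the entering group is larger than anything tried so far. Compound 4 is therefore estimated at 40 nM in this assay, within a range of 13 nM to 120 nM.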

Compound 4, half-maximal inhibitory concentration: 40 nM
For compound 4 middle estimate and measured number coincide at the digits printed; the range from low to high includes it.
By their numbers in this assay, from the lowest: compounds 2, 3, 4 and 1 (each within the scatter of the next).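

For the compounds shown here, on the sulfur, 4-methoxy-2-nitrophenyl in place of phenyl gives no change at the digits printed from compound 3 to compound 4 (within the scatter) in this assay, and this is the first step that alters the substitution of the aryl group on that sulfur rather than exchanging the whole aryl-bearing group. The change is a sizeable one by count, with 11 heavy atoms entering for 6 and 3 hydrogen-bond acceptors for 0, yet the number stays where it was, so at this position, for this one pair, a much larger substituted aryl group leaves the read-out unmoved. Nothing available here accounts for why the number holds across this change.

Since 4-methoxy-2-nitrophenyl is the only substituted aryl group on the sulfur among the compounds shown, what its methoxy and nitro groups each contribute on their own remains open. Also open, on these data alone, is whether the number would hold with an amine or a carboxylic acid on that aryl ring, or with a longer chain on the sulfur in place of the aryl group.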